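Working notes: chloro on the phenyl group of compound 3

The source may report more compounds than this note shows. Statements on the series, on what has been measured and on what is new or still open speak of the compounds shown alone.

Measured so far in a functional assay on A549 cells (Homo sapiens) for cytotoxicity, read by MTT assay, with a stated time of 48 h; a lower number here means a stronger inhibitor, a higher number a weaker inhibitor:
compound 1 `CCOC(=O)c1c(-c2cc3ccccc3oc2=O)nn(-c2ccccc2)c1C(=O)OCC`: 100000 nM
compound 2 `CCOC(=O)c1c(-c2cc3ccccc3oc2=O)nn(-c2cccc(Cl)c2)c1C(=O)OCC`: 28000 nM
compound 3 `CCOC(=O)c1c(-c2cc3ccc(OC)cc3oc2=O)nn(-c2ccccc2)c1C(=O)OCC`: 132000 nM

Compound 3 carries the highest number of the three. Its gap to compound 1 lies within the scatter, so no order between these two can be read. Compound 2 gives a lower number than compound 3, and that gap lies beyond the scatter.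

Compound 4 `CCOC(=O)c1c(-c2cc3ccc(OC)cc3oc2=O)nn(-c2cccc(Cl)c2)c1C(=O)OCC` differs from compound 3 in one place: chloro in place of hydrogen on an aromatic carbon. The same change has been measured once in this series, from the parent without methoxy: a 3.6-fold lower number from compound 1 to compound 2 (0.55 log units; beyond the scatter). The methoxy change itself, a 1.3-fold higher number from compound 1 to compound 3 (0.12 log units; within the scatter), stayed within the scatter, so the methoxy-bearing and the unsubstituted parents look alike on the numbers available. Within the data shown here, with one example of the chloro step and one of the methoxy step, no claim can be made beyond these compounds, but the single chloro step is the only guide for the step from compound 3 to compound 4.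

For compound 4 a lower number of similar size is expected, a 3.6-fold lower number from compound 3 to compound 4 (0.55 log units; beyond the scatter). The estimate for compound 4 in this assay is 37000 nM, with a range from 15000 nM to 90000 nM.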

Compound 4, half-maximal inhibitory concentration: 221000 nM
Compound 4: the middle estimate sits 6.0-fold (0.78 log units) below what was measured, and the stated range ends below it.
By their numbers in this assay, from the lowest: compound 2; then compounds 1, 3 and 4 (each within the scatter of the next, the first and the last beyond it).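

In this assay, the chloro change on the phenyl group does not carry over from one core to the other: a 1.7-fold higher number from compound 3 to compound 4 (0.22 log units; within the scatter) gives no readable shift, unlike the step on the core without methoxy: the same change on two cores in this assay, a 3.6-fold lower number (0.55 log units; beyond the scatter) from compound 1 to compound 2 and a 1.7-fold higher number (0.22 log units; within the scatter) from compound 3 to compound 4, 6.0-fold (0.78 log units) apart, beyond the scatter of two such steps

The methoxy change, which gave no readable shift on the phenyl parent, is not silent on the 3-chlorophenyl parent, where the result is a 7.9-fold higher number from compound 2 to compound 4 (0.90 log units; beyond the scatter), so its reading depends on the group at the other end of the molecule: the same change on two cores in this assay, a 1.3-fold higher number (0.12 log units; within the scatter) from compound 1 to compound 3 and a 7.9-fold higher number (0.90 log units; beyond the scatter) from compound 2 to compound 4, 6.0-fold (0.78 log units) apart, beyond the scatter of two such steps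

The two changes therefore do not add across these four compounds, and the lower number of compound 2 belongs to the pairing of 3-chlorophenyl with the core lacking methoxy, while compound 4 goes against any rule that chloro alone lowers the number.

From the compounds shown here alone, whether a hydroxy group or an amine in place of methoxy, or fluoro or a carboxylic acid in place of chloro, would show the same dependence stays open. Among these compounds, with only one pair on each core, it also stays open whether this difference between the cores holds beyond compounds 1 to 4.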